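The source may report more compounds than this note shows. Statements on the series, on what has been measured and on what is new or still open speak of the compounds shown alone.

Compound 1 `OC[C@H]1O[C@@H](n2cnc3c(SCc4ccccc4Cl)ncnc32)[C@H](O)[C@@H]1O` — 117 nM
Compound 2 `OC[C@H]1O[C@@H](n2cnc3c(SCc4ccccc4I)ncnc32)[C@H](O)[C@@H]1O` — 19.5 nM

Both compounds were tested in an assay on isolated protein for inhibition of Equilibrative nucleoside transporter 1 (Homo sapiens); on this read-out higher numbers stand for weaker inhibition and lower numbers for stronger inhibition. Going by the values given here, compound 2 gives the lower of the two numbers; the only other measured compound, compound 1, stands higher, and the step of a 6.0-fold lower number from compound 1 to compound 2 (0.78 log units; beyond the scatter) lies beyond the scatter. Compound 3 `N#Cc1ccccc1CSc1ncnc2c1ncn2[C@@H]1O[C@H](CO)[C@@H](O)[C@H]1O` has not yet been measured. It differs from compound 2 in one place: cyano in place of iodo on an aromatic carbon. A single measured step bears on this position, a 6.0-fold lower number from compound 1 to compound 2 (0.78 log units; beyond the scatter), which shows that exchanging the group on this aromatic carbon can move the number clearly, with the halogen exchange lowering it. Among the compounds with values here, no measured pair shows what cyano does at this carbon, so the direction is uncertain, and a shift back toward higher numbers, of modest size, seems more likely than a further drop. Compound 3 is therefore expected to give about 100 nM in this assay, within a range from 30 nM to 350 nM. That estimate corresponds to the expected step of a 5.1-fold higher number from compound 2 to compound 3 (0.71 log units; beyond the scatter).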

Compound 3, inhibition constant: 38.9 nM
Compound 3: the middle estimate sits 2.6-fold (0.41 log units) above what was measured; measured number inside the range.
By their numbers in this assay, from the lowest: compounds 2 and 3 (each within the scatter of the next); then compound 1.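

Measured in this assay, cyano in place of iodo gives a 2.0-fold higher number from compound 2 to compound 3 (0.30 log units; within the scatter) and so the two compounds cannot be told apart on this read-out. Cyano in place of chloro gives a 3.0-fold lower number from compound 1 to compound 3 (0.48 log units; beyond the scatter) and so shows that, at this aromatic carbon, a group that is not a halogen can also give a number clearly lower than the chloro compound's. No measurement at hand accounts for these differences.

The compounds shown leave open what an amine, a carboxylic acid or a methoxy group would do on this same aromatic carbon. They also leave open whether cyano and iodo would still give numbers within the scatter of each other if placed on a different carbon of this ring.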